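The compounds below may be only part of what the source reports. "The series", "measured", "known", "first", "only" and "open" are said of these compounds alone.

Measured compounds: compound 1 is `O=C1NCCN1C(c1ccccc1)(c1ccccc1)c1ccccc1`, which gives > 100000 nM, a limit. Compound 2 is `COc1cc(NC(C)CCCNC(=O)Nc2ccc(Cl)c(C(F)(F)F)c2)c2ncccc2c1`, which gives 28000 nM.

The numbers come from a functional assay on NCI-H460 cells (Homo sapiens) for inhibition, read by MTT assay, with a stated time of 4 days; a higher number here means a weaker inhibitor, a lower number a stronger inhibitor. Compound 1 gives only a limit there, > 100000 nM, and not a number. Compound 2 gives 28000 nM in this assay, the only number shown, so it stands alone with nothing measured to set beside it. The other value shown is the limit of compound 1, as the limit of > 100000 nM in this assay, at which 1 of the 2 values shown sits, records. Compound 3, `COc1cc(NC(C)CCCNC(=O)NNC(=O)NCCO)c2ncccc2c1`, has not yet been measured. It differs from compound 2 in one place: ((2-hydroxyethyl)carbamoyl)amino in place of 4-chloro-3-(trifluoromethyl)phenyl on an amide-type nitrogen. Among the compounds with values here, no step between measured compounds is available, so the size of this change can only be guessed. The expectation is for a move to weaker inhibition, beyond the scatter, of a 2.1-fold higher number from compound 2 to compound 3 (0.33 log units; beyond the scatter). Compound 3 is thus estimated at 60000 nM, within 20000 nM to 180000 nM, with a fair chance that this assay reports only a limit.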

Compound 3, half-maximal inhibitory concentration: > 100000 nM
Compound 3 was reported as a limit; the forecaster's own chance of this, stated with the estimate: 40%; middle value at least 1.6-fold (0.22 log units) from the limit.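

In this assay compound 3 gives only a limit, > 100000 nM, and not a number. Placing ((2-hydroxyethyl)carbamoyl)amino where 4-chloro-3-(trifluoromethyl)phenyl stood on an amide-type nitrogen gives the first step read at this position, an at least 3.5-fold higher number from compound 2 to compound 3 (0.55 log units; beyond the scatter), so this place is sensitive to the change, and the aromatic group is the better of the two. The step has a floor but no upper end, and its full size cannot be read: the limit of > 100000 nM in this assay, at which 2 of the 3 values shown sit.

This single step removes the ring and the halogens and brings in the open chain all at once, so it does not tell which of these carries the loss. On these data alone, whether a plain phenyl, a 4-chlorophenyl or a short chain ending in an amine would hold the activity of compound 2 remains open.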